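A few compounds are considered here, and "the series" means these few. Any claim that something is new, unique, unknown or untested is made for them only; others in the source may bear on it.

The measured compounds in an ADME assay for permeability, using PAMPA, with a stated time of 30 min, at pH 7.4 (on this read-out higher numbers stand for higher permeability and lower numbers for lower permeability), are: compound 1 `c1ccc(-c2ccc3c(NCCCNCc4ccco4)ccnc3c2)cc1` with 237 10^-6 cm/s; compound 2 `COc1cccc(CNCCCNc2ccnc3cc(Cc4ccccc4)ccc23)c1O` with 23 10^-6 cm/s; compound 3 `COc1cccc(CNCCCNc2ccnc3cc(-c4ccccc4)ccc23)c1O` with 237 10^-6 cm/s.

Compound 1 stands level with compound 3 at the digits shown, and these two give the highest numbers of the three, while compound 2 lies well below: a 10-fold higher number from compound 2 to compound 3 (1.01 log units; beyond the scatter). Compound 4 `COc1ccc(-c2ccc3c(NCCCNCc4ccco4)ccnc3c2)cc1` differs from compound 1 by methoxy in place of hydrogen on an aromatic carbon. For the measured compounds named here, no measured step adds a group to this ring. The step of no change at the digits printed from compound 1 to compound 3 (within the scatter) alters the other end of the molecule, and a 10-fold higher number from compound 2 to compound 3 (1.01 log units; beyond the scatter) is a change of a different kind. Compound 4 is therefore expected to sit close to compound 1, with a 1.2-fold lower number from compound 1 to compound 4 (0.07 log units; within the scatter). The estimate for compound 4 is 200 10^-6 cm/s, between 100 10^-6 cm/s and 320 10^-6 cm/s.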

Compound 4, apparent permeability: 237 10^-6 cm/s
Compound 4: the middle estimate sits 1.2-fold (0.07 log units) below what was measured, within the range that was stated.
By their numbers in this assay, from the lowest: compound 2; then compounds 1, 3 and 4 (each within the scatter of the next).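

Methoxy in place of hydrogen, on the aromatic carbon para to a large group, is the first change at this ring among the compounds shown, and it leaves the reading in this assay level (no change at the digits printed from compound 1 to compound 4 (within the scatter)). The earlier steps shown here changed the other end of the molecule or swapped benzyl for phenyl, so they said nothing about adding a group here. No evidence at hand explains this result.

From the compounds shown here alone, whether an amine or a carboxylic acid at this place would also leave the number level remains open. So does whether methoxy behaves the same way in compound 3, which carries 2-hydroxy-3-methoxyphenyl instead of furan-2-yl.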